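The source may hold more compounds than are shown below. What is called first, only, known or untested is meant among the compounds shown, and "the series" means these compounds.

Compound 1, `C=CCN(C)C(=O)c1ccc(C(CC)(CC)c2ccc(OCCC(O)(CC)CC)c(C)c2)n1CC`: 1190 nM
Compound 2, `CCn1c(C(=O)Nc2cccc(C(F)(F)F)c2)ccc1C(CC)(CC)c1ccc(OCCC(O)(CC)CC)c(C)c1`: > 50000 nM
Compound 3, `CCOC(=O)CN(C)C(=O)c1ccc(C(CC)(CC)c2ccc(OCCC(O)(CC)CC)c(C)c2)n1CC`: 1990 nM

In an ADME assay on L02 cells (Homo sapiens) for antiproliferative activity, read by MTT assay, with a stated time of 48 h (on this read-out lower numbers stand for stronger inhibition and higher numbers for weaker inhibition), compound 3 gives 1990 nM, which lies within the scatter of compound 1 at 1190 nM. Compound 2 reads > 50000 nM, which is a limit of the assay and not a number.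

Compound 4, `CCn1c(C(=O)N(C)CCO)ccc1C(CC)(CC)c1ccc(OCCC(O)(CC)CC)c(C)c1`, has not yet been measured. It differs from compound 3 at one place: hydroxymethyl in place of ethoxycarbonyl on a saturated chain carbon bound to an amide-type nitrogen. The (ethoxycarbonyl)methyl group thus becomes 2-hydroxyethyl, while the methyl on the amide-type nitrogen and the shared core stay.

The closest evidence is the change at this same place, a 1.7-fold higher number from compound 1 to compound 3 (0.22 log units; within the scatter), which stayed within the scatter. The large steps, an at least 42-fold higher number from compound 1 to compound 2 (1.62 log units; beyond the scatter) and an at least 25-fold lower number from compound 2 to compound 3 (1.40 log units; beyond the scatter), both involve the (3-(trifluoromethyl)phenyl)amino group of compound 2, which compound 4 lacks, so they bear on it only weakly.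

The expected change is a 1.1-fold higher number from compound 3 to compound 4 (0.04 log units; within the scatter), with no step beyond the scatter anticipated. For compound 4 the estimate is 2200 nM, with an expected range from 800 nM to 6500 nM.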

Compound 4, half-maximal inhibitory concentration: 2050 nM
For compound 4 the middle estimate is 1.1-fold (0.03 log units) above the measured one; measured number inside the range.
By their numbers in this assay, from the lowest: compounds 1, 3 and 4 (each within the scatter of the next). At a limit, above all of these: compound 2.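

In this assay, the chain on the amide-type nitrogen accepts a further end group without a shift beyond the scatter: a 1.0-fold higher number from compound 3 to compound 4 (0.01 log units; within the scatter), and a 1.7-fold higher number from compound 1 to compound 4 (0.24 log units; within the scatter). The earlier compounds shown here compared only vinyl and ethoxycarbonyl at this place, whereas the hydroxymethyl of compound 4 brings a hydrogen-bond donor onto this chain, and the three compounds still read alike. The large step, an at least 24-fold lower number from compound 2 to compound 4 (1.38 log units; beyond the scatter), starts from a limit of the assay and not a number: the limit of > 50000 nM in this assay, at which 1 of the 4 values shown sits.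

The compounds shown leave open whether an amine or a carboxylic acid on this chain would also stay within the scatter. They also do not show whether a longer chain ending in hydroxyl, or a ring on the amide-type nitrogen in place of the open chain, would do so.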